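Aryl swap on the oxadiazole of the pyridazinone series

The source may hold more compounds than are shown below. What is called first, only, known or untested is meant among the compounds shown, and "the series" means these compounds.

Measured compounds:
- compound 1 `COc1c(F)c(F)cc(-c2nnc(COc3cnn(C(C)(C)C)c(=O)c3Cl)o2)c1F`: > 300 ug/mL in a functional assay on the whole organism for inhibition, with Mythimna separata as the target, with a stated time of 5 days; a higher number here means that more compound is needed for the effect, a lower number that less compound is needed (a limit of the assay)
- compound 2 `CC(C)(C)n1ncc(OCc2nnc(-c3cc(F)c(F)cc3F)o2)c(Cl)c1=O`: 75.7 ug/mL
- compound 3 `CCCCn1ncc(OCc2nnc(-c3ccc(Cl)cc3)o2)c(Cl)c1=O`: 224 ug/mL

Compound 2 gives the lowest of the two numbers in this assay. Compound 3 gives a higher number, beyond the scatter. For compound 1 this assay gives only a limit, (the limit of > 300 ug/mL in this assay, at which 1 of the 3 values shown sits), and no number.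

The next compound, compound 4 `CCc1ccc(-c2nnc(COc3cnn(C(C)(C)C)c(=O)c3Cl)o2)cc1`, is not yet measured. It differs from compound 2 by 4-ethylphenyl in place of 2,4,5-trifluorophenyl on an aromatic carbon.

Going by the values given here, only one measured step touches the aryl ring on the shared core: an at least 3.9-fold lower number from compound 1 to compound 2 (0.59 log units; beyond the scatter), which shows that a change on that ring can move the number beyond the scatter. Among the compounds with values here, no measured pair exchanges the whole aryl ring while the rest is held fixed; compound 3 carries a different aryl ring but also a different alkyl on the core, so its value shows only that such a combination lands at 224 ug/mL. The direction of the step from compound 2 to compound 4 is therefore open.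

Compound 4 is expected near 160 ug/mL, within 45 ug/mL to 300 ug/mL, with the step of a 2.1-fold higher number from compound 2 to compound 4 (0.33 log units; beyond the scatter) estimated as a loss of potency, wide in its uncertainty.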

Compound 4, half-maximal effective concentration: 14.5 ug/mL
Compound 4: the middle estimate sits 11-fold (1.04 log units) above what was measured, and the stated range ends above it.
By their numbers in this assay, from the lowest: compound 4; then compound 2; then compound 3. At a limit, above all of these: compound 1.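

With the shared core held fixed, placing 4-ethylphenyl in place of 2,4,5-trifluorophenyl on this aromatic carbon of the five-membered ring gives a 5.2-fold lower number from compound 2 to compound 4 (0.72 log units; beyond the scatter) in this assay. This is the only exchange of the whole aryl ring shown with the rest of the molecule unchanged, and it shows that this position accepts a ring with no fluorine and a carbon chain while the number still falls beyond the scatter; the earlier step showed only that changing one group on a fluorinated ring can move the number. Nothing measured here bears on why the exchange lowers the number.

The removal of the three fluorines and the arrival of the ethyl group happen in the same step, so this single pair cannot assign the change to either one, and it gives no trend across aryl rings. An unsubstituted phenyl ring would separate those two parts, while a propyl or longer chain in place of the ethyl, or an amine on the ring, would show how far the position extends.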